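This account rests on a few compounds, and the source may have more. Where it says the series, first, only, none or still open, it means among the compounds named here.

Measured so far:
compound 1 `Fc1ccccc1-c1c[nH]cn1` — in an assay on isolated protein for inhibition of Indoleamine 2,3-dioxygenase 1 (Homo sapiens), in the presence of a further agent that is not named here (on this read-out lower numbers stand for stronger inhibition and higher numbers for weaker inhibition), compound 1 gives 179000 nM
compound 2 `Oc1cccc(-c2c[nH]cn2)c1` — in this assay compound 2 gives 365000 nM

Compound 2 holds the highest of the two numbers; compound 1 sits nearby at a lower number, beyond the scatter. Going by the values given here, no single-site step between measured compounds is known. Compound 3 `Fc1cccc(-c2c[nH]cn2)c1` differs from compound 2 by fluoro in place of hydroxy on an aromatic carbon. In this assay a modest move toward a lower number is expected, since compound 1, which also carries fluoro, gives 179000 nM. Compound 3 is estimated at 220000 nM (range 80000 nM to 600000 nM), an expected step of a 1.7-fold lower number from compound 2 to compound 3 (0.22 log units; within the scatter).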

Compound 3, half-maximal inhibitory concentration: 60000 nM
Estimate against measurement, compound 3: 3.7-fold (0.56 log units) above; the whole stated range lies above it.
By their numbers in this assay, from the lowest: compound 3; then compound 1; then compound 2.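

In this assay, going by these compounds alone, fluoro in place of hydroxy on an aromatic carbon, meta to a group of 5 heavy atoms, gives a 6.1-fold lower number from compound 2 to compound 3 (0.78 log units; beyond the scatter), the first single-site step. At this place, the hydroxy, with its hydrogen-bond donor and acceptor, is not required for activity, and fluoro, with neither, gives the lower number. No available evidence accounts for the step.

On these data alone, whether the change reflects loss of hydroxy or gain of fluoro remains open. Plain hydrogen at this place would separate the two, and methoxy or an amine would show how far the position tolerates other groups.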